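The compounds below may be only part of what the source reports. "The series", "measured", "known", "first", "only" and "open" are said of these compounds alone.

Of the compounds shown here, two have been measured in a physicochemical assay for lipophilicity; a higher number here means a more lipophilic compound, a lower number a more polar compound. Compound 1 `CCCCS(=O)(=O)c1ccc(O)c(C(=O)Nc2ccc(Br)cc2)c1` gives 4.12, and compound 2 `CCCCCCCCCCCCS(=O)(=O)c1ccc(O)c(C(=O)Nc2ccc(C(F)(F)F)cc2)c1`, which carries a dodecyl chain, gives 8.46. That is the higher of the two numbers, and its gap to compound 1 lies beyond the scatter. The two compounds differ in more than one place, so this gap cannot be assigned to any single change. Compound 3 `CCCCCCCCCCCCS(=O)(=O)c1ccc(O)c(C(=O)Nc2ccc(Br)cc2)c1` keeps the dodecyl chain of compound 2 but has bromo in place of trifluoromethyl on an aromatic carbon, para to a large group: bromo in place of trifluoromethyl on an aromatic carbon. It thereby shares the 4-bromophenyl of compound 1. No step beyond the scatter is expected in this assay from this swap, taking compound 2 at 8.46 as the starting point. The expected change is a number 0.06 log units lower from compound 2 to compound 3 (within the scatter). Compound 3 is estimated at 8.4, with a range from 8.1 to 8.7.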

Compound 3, partition coefficient: 8.44
Compound 3: the middle estimate sits 0.04 log units below what was measured; measured number inside the range.
By their numbers in this assay, from the lowest: compound 1; then compounds 3 and 2 (each within the scatter of the next).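

In this assay, bromo in place of trifluoromethyl on this aromatic carbon, para to a large group, gives a number 0.02 log units lower from compound 2 to compound 3 (within the scatter), so the two groups cannot be told apart here when the dodecyl chain is present. Among these compounds, compound 3 also isolates the chain for the first time: octyl in place of hydrogen on a saturated chain carbon, four bonds along the chain from a sulfonyl sulfur, gives a number 4.32 log units higher from compound 1 to compound 3 (beyond the scatter), a large step with the 4-bromophenyl held constant. Nothing available explains the size of either step.

Going by these compounds, whether bromo and trifluoromethyl also stay within the scatter of each other on the shorter chain of compound 1 remains open. So do the effect of a nitrile or a carboxylic acid at this aromatic position and the course of the number at chain lengths between these two, such as a hexyl chain.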